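This account rests on a few compounds, and the source may have more. Where it says the series, first, only, none or still open, it means among the compounds named here.

Measured in a functional assay on C6 cells (Rattus norvegicus) for cytotoxicity, read by MTT assay, with a stated time of 24 h, tested at 6 ug/mL; on this read-out higher numbers stand for a weaker effect at the one concentration tested and lower numbers for a stronger effect:
compound 1 `Cc1ccc(-c2cs/c(=N/NC(=O)CSc3nnnn3-c3ccccc3)n2-c2ccccc2)cc1` gives 66.8%
compound 2 `Cn1cnnc1SCC(=O)N/N=c1/scc(-c2ccc(C#N)cc2)n1-c1ccccc1` gives 70.2%
compound 3 `COc1ccc(-c2cs/c(=N/NC(=O)CSc3nnc(C)s3)n2-c2ccccc2)cc1` gives 57.9%

Among these three numbers, compound 1 lies apart from compound 2 by a gap within the usual scatter, and apart from compound 3 likewise, so none of the three can be told from the others in this assay. Compound 4 `O=C(CSc1nnnn1-c1ccccc1)N/N=c1/scc(-c2ccc(F)cc2)n1-c1ccccc1` has not yet been measured. It differs from compound 1 by a single change: fluoro in place of methyl on an aromatic carbon. The group that leaves and the group that enters are each a single heavy atom. Going by the values given here, no measured pair shows such a swap, so the expected step is a number 0.8 percentage points lower from compound 1 to compound 4 (within the scatter), small and not beyond the scatter in either direction. Compound 4 is therefore estimated at 66%, between 55% and 77%.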

Compound 4, a percentage reported as activity, at one concentration (the size of the read-out at that concentration, not a potency): 74.9%
For compound 4 the middle estimate is 8.9 percentage points below the measured one; low and high end bracket the measured number.
By their numbers in this assay, from the lowest: compounds 3, 1, 2 and 4 (each within the scatter of the next, the first and the last beyond it).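

Going by these compounds alone, this is the first direct comparison at this place on the aromatic ring, where 4-methylphenyl becomes 4-fluorophenyl. In this assay, the change gives a number 8.1 percentage points higher from compound 1 to compound 4 (within the scatter), so this swap of one single-atom group for another cannot be told from repeat-measurement noise. No measurement shown offers an explanation for the step. Going by these compounds, it remains open whether an amine, a carboxylic acid or a longer chain at this place would shift the read-out beyond the scatter. On these data alone, whether the same swap behaves alike with a different side chain on the shared core is also open.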